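Methoxy in Place of Trifluoromethyl: What to Expect

The source may report more compounds than this note shows. Statements on the series, on what has been measured and on what is new or still open speak of the compounds shown alone.

Three compounds sharing one core were tested in a functional assay on HeLa cells (Homo sapiens) for antiproliferative activity, read by MTT assay, with a stated time of 48 h; a lower number here means a stronger inhibitor, a higher number a weaker inhibitor. Compound 1 `COc1cc(-c2nnc(SCC(=O)c3ccc(Cl)cc3)n2N)cc(OC)c1OC` gives 13100 nM. Compound 2 `COc1cc(-c2nnc(SCC(=O)c3ccc(C(F)(F)F)cc3)n2N)cc(OC)c1OC` gives 3380 nM, which is the lowest of the two numbers reported. Compound 3 `COc1cc(-c2nnc(SCC(=O)c3ccc(F)c(F)c3)n2N)cc(OC)c1OC` sits at the limit of > 100000 nM in this assay, at which 1 of the 3 values shown sits, reported as > 100000 nM, so for compound 3 no number is known. The measured steps read: a 3.9-fold lower number from compound 1 to compound 2 (0.59 log units; beyond the scatter); an at least 29-fold higher number from compound 2 to compound 3 (1.47 log units; beyond the scatter); and an at least 7.6-fold higher number from compound 1 to compound 3 (0.88 log units; beyond the scatter).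

Compound 4 `COc1ccc(C(=O)CSc2nnc(-c3cc(OC)c(OC)c(OC)c3)n2N)cc1` differs from compound 2 in one place: methoxy in place of trifluoromethyl on an aromatic carbon. Among the compounds with values here, two measured steps bear on this change. The trifluoromethyl of compound 2 gave a lower number than the chloro of compound 1, as shown by a 3.9-fold lower number from compound 1 to compound 2 (0.59 log units; beyond the scatter), and exchanging that same group as part of a larger change left compound 3 at the limit, as shown by an at least 29-fold higher number from compound 2 to compound 3 (1.47 log units; beyond the scatter). Every replacement of trifluoromethyl seen so far has raised the number, so in this assay a higher number than compound 2 is expected for compound 4, by a step of roughly a 5.9-fold higher number from compound 2 to compound 4 (0.77 log units; beyond the scatter). Compound 4 is therefore estimated at 20000 nM, with a range from 5000 nM to 100000 nM.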

Compound 4, half-maximal inhibitory concentration: 17400 nM
For compound 4 the middle estimate is 1.1-fold (0.06 log units) above the measured one; the range from low to high includes it.
By their numbers in this assay, from the lowest: compound 2; then compounds 1 and 4 (each within the scatter of the next). At a limit, above all of these: compound 3.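

In this assay, within the data shown here, the 4-(trifluoromethyl)phenyl group now keeps its lead over a second, quite different replacement, with a 5.1-fold higher number from compound 2 to compound 4 (0.71 log units; beyond the scatter); until now, chloro was the only single-group comparison at this position. Methoxy brings an oxygen where trifluoromethyl carries three fluorines, yet it cannot be told apart from chloro at this position, with a 1.3-fold higher number from compound 1 to compound 4 (0.12 log units; within the scatter), so two unlike groups give numbers within the usual scatter of each other and trifluoromethyl alone stands clear of them. The 4-methoxyphenyl group also gives a measurable value where the 3,4-difluorophenyl group does not, with an at least 5.7-fold lower number from compound 3 to compound 4 (0.75 log units; beyond the scatter), and that step stays open-ended, as compound 3 is recorded at a limit of the assay and not at a number: the limit of > 100000 nM in this assay, at which 1 of the 4 values shown sits.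

Among these compounds, with only three groups compared at this one position, these compounds do not show why trifluoromethyl gives the lowest number, nor whether any other group could go lower. An amine, a carboxylic acid or a longer chain such as ethoxy on the same aromatic carbon would test whether trifluoromethyl remains the exception or whether the number can be moved further in either direction.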